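Acetoxy for methoxy on the aryl of compound 1

The compounds below may be only part of what the source reports. "The series", "measured", "known", "first", "only" and "open" are said of these compounds alone.

Compound 1 `COc1ccc(-c2cc3c(OC)cc(OC)cc3n(C)c2=O)cc1` gives 10000 nM in a functional assay on T47D cells (Homo sapiens) for cytotoxicity, read by colorimetric assay and MTT assay; a higher number here means a weaker inhibitor, a lower number a stronger inhibitor. Compound 2 `CCN(CC)C(=O)Cn1c(=O)c(-c2ccc(OC)cc2)cc2c(OC)cc(OC)cc21` gives 10000 nM in this assay, and compound 3 `COc1ccc(-c2cc3c(OC)cc(OC)cc3n(CCCC#N)c2=O)cc1` gives 10000 nM. Compound 1 thus stands level with compounds 2 and 3 at the digits shown: the steps of no change at the digits printed from compound 1 to compound 2 (within the scatter), no change at the digits printed from compound 1 to compound 3 (within the scatter) and no change at the digits printed from compound 2 to compound 3 (within the scatter) are all within the scatter. Every measured step in the series replaces one group with another on a saturated chain carbon bound to an aromatic nitrogen, and none of them moved the read-out.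

Compound 4 `COc1cc(OC)c2cc(-c3ccc(OC(C)=O)cc3)c(=O)n(C)c2c1` differs from compound 1 at another place: acetyl in place of methyl on an oxygen on an aromatic ring. Going by the values given here, no measured step touches this oxygen on an aromatic ring, so nothing in the data speaks for a shift in either direction. With three compounds sharing one read-out across unrelated changes, the expected step is no change at the digits printed from compound 1 to compound 4 (within the scatter), none beyond the scatter. Compound 4 is therefore estimated at 10000 nM, with a range of 5000 nM to 20000 nM.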

Compound 4, half-maximal inhibitory concentration: 10000 nM
Compound 4: the middle estimate sits on the measured number at the digits printed, and the stated range covers the measured number.
By their numbers in this assay, from the lowest: compounds 1, 2, 3 and 4 (each within the scatter of the next).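

The series now holds a change away from the saturated chain carbon bound to an aromatic nitrogen: acetyl in place of methyl on an oxygen on an aromatic ring gives no change at the digits printed from compound 1 to compound 4 (within the scatter) in this assay. The shared read-out is therefore not confined to one site, and the larger acetyl, with its carbonyl and hydrogen-bond acceptor, does not separate compound 4 from compound 1 at this oxygen. No available evidence bears on this result.

Going by these compounds, whether a free hydroxyl, an aminoalkyl ether or a longer ester such as butanoyl on this oxygen would move the read-out remains open. With all four compounds level, neither site yet shows which direction of change would strengthen inhibition in this assay.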